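Phenylsulfonyl Gives Way to Benzoyl: An Expectation

The source may report more compounds than this note shows. Statements on the series, on what has been measured and on what is new or still open speak of the compounds shown alone.

Compound 1, `CC(=O)/C(=C\c1c(-c2ccccc2)[nH]c2ccccc12)S(=O)(=O)c1ccccc1`, gives 3800 nM.
Compound 2, `N#C/C(=C\c1c(-c2ccccc2)[nH]c2ccccc12)S(=O)(=O)c1ccccc1`, gives 5600 nM.

Among the compounds with values here, in a functional assay on TK-10 cells (Homo sapiens) for inhibition, read by sulforhodamine B assay, with a stated time of 48 h (a higher number here means a weaker inhibitor of growth, a lower number a stronger inhibitor of growth), compound 2 stands highest of the two numbers, yet the single measured step, a 1.5-fold higher number from compound 1 to compound 2 (0.17 log units; within the scatter), lies within the scatter, so the two compounds are not distinguishable there. Compound 3, `N#C/C(=C\c1c(-c2ccccc2)[nH]c2ccccc12)C(=O)c1ccccc1`, differs from compound 2 by benzoyl in place of phenylsulfonyl on a double-bonded chain carbon bound to a double-bonded chain carbon and a triple-bonded carbon. Within the data shown here, no measured step touches that part of the chain; the one step known changed the other substituent and stayed within the scatter. In this assay compound 3 is therefore expected to give about 5000 nM, between 1500 nM and 16000 nM, an estimated step of a 1.1-fold lower number from compound 2 to compound 3 (0.05 log units; within the scatter).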

Compound 3, concentration for 50% growth inhibition: 11100 nM
Estimate against measurement, compound 3: 2.2-fold (0.35 log units) below, and the stated range covers the measured number.
By their numbers in this assay, from the lowest: compounds 1, 2 and 3 (each within the scatter of the next, the first and the last beyond it).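

Within the data shown here, with the nitrile kept, benzoyl in place of phenylsulfonyl gives a 2.0-fold higher number from compound 2 to compound 3 (0.30 log units; within the scatter), the first measured step at this part of the chain. Compound 2 and compound 3 therefore cannot be told apart, and the sulfonyl group can give way to a carbonyl with growth inhibition staying in the same range. Nothing available explains these numbers.

From the compounds shown here alone, whether an amine, a carboxylic acid or a methyl ester would be accepted at this place remains open. So does whether benzoyl would behave alike with acetyl in place of the nitrile.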